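Melanocortin receptor 4 series: amide variants at the benzylic amine

This account rests on a few compounds, and the source may have more. Where it says the series, first, only, none or still open, it means among the compounds named here.

Measured so far in an assay on HEK293 cells for displacement of a labelled ligand from Melanocortin receptor 4 (Homo sapiens); a lower number here means a stronger inhibitor, a higher number a weaker inhibitor:
- compound 1 `CC[C@H](C)C(N)c1cc(C(F)(F)F)ccc1N1CCN(C(=O)CCc2ccc(Cl)cc2Cl)CC1`, compound 1 gives 75 nM
- compound 2 `CCC(C)[C@H](NC[C@@H]1CCCN1)c1cc(C(F)(F)F)ccc1N1CCN(C(=O)CCc2ccc(Cl)cc2Cl)CC1`, compound 2 gives 64 nM
- compound 3 `CCC(C)[C@H](NC(C)=O)c1cc(C(F)(F)F)ccc1N1CCN(C(=O)CCc2ccc(Cl)cc2Cl)CC1`, compound 3 gives 360 nM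

Compound 3 holds the highest number of the three. The steps leading to it are a 4.8-fold higher number from compound 1 to compound 3 (0.68 log units; beyond the scatter) and a 5.6-fold higher number from compound 2 to compound 3 (0.75 log units; beyond the scatter); both are modest yet beyond the scatter. By contrast a 1.2-fold lower number from compound 1 to compound 2 (0.07 log units; within the scatter), so the free amine and the secondary amine carrying a (pyrrolidin-2-yl)methyl group sit together, and only the acetylated nitrogen of compound 3 falls off.

Compound 4 `CC(C)C[C@H](NC(=O)CN)c1cc(C(F)(F)F)ccc1N1CCN(C(=O)CCc2ccc(Cl)cc2Cl)CC1` is not yet measured. The change from compound 3 is 1-(((aminomethyl)carbonyl)amino)-3-methylbutyl in place of 1-acetamido-2-methylbutyl on an aromatic carbon. The aromatic carbon that carries the group is ortho to a large group and meta to a trifluoromethyl group, as in the rest of the series.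

Among the compounds with values here, two steps bear on the expectation. Compound 3 shows what capping the nitrogen with acetyl costs, and compound 2 shows that a nitrogen bearing a (pyrrolidin-2-yl)methyl group holds the number of compound 1. Compound 4 keeps the amide of compound 3 but adds an aminomethyl to it, so a partial recovery is expected. For compound 4 the expected step is a 2.4-fold lower number from compound 3 to compound 4 (0.38 log units; beyond the scatter). For compound 4 the estimated value is 150 nM, with a range from 50 nM to 500 nM.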

Compound 4, inhibition constant: 19 nM
Beside the measured number, compound 4's estimate is 7.9-fold (0.90 log units) above it; the whole stated range lies above it.
By their numbers in this assay, from the lowest: compound 4; then compounds 2 and 1 (each within the scatter of the next); then compound 3.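

In this assay the amide at this nitrogen turns out not to be a liability in itself: the change of cap and chain gives a 19-fold lower number from compound 3 to compound 4 (1.28 log units; beyond the scatter) and removes the loss seen with the acetamide of compound 3. The amide of compound 4 also goes past both amines, with a 3.9-fold lower number from compound 1 to compound 4 (0.60 log units; beyond the scatter) and a 3.4-fold lower number from compound 2 to compound 4 (0.53 log units; beyond the scatter), so compound 4 is the strongest of the four and the benzylic nitrogen need not stay an amine to hold or improve the number. The entering group differs from the leaving one in two parts, the 3-methylbutyl chain in place of the 2-methylbutyl chain and the aminomethyl on the carbonyl in place of the acetyl methyl, and no supporting data bear on why the number falls.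

Open, from the compounds shown here alone, is how the step divides between those two parts, which the acetamide on the 3-methylbutyl chain or the aminomethyl amide on the 2-methylbutyl chain would settle. Also open, going by these compounds, is what the amide cap tolerates, for instance a dimethylamino group in place of the primary amine, a longer chain carrying the amine, or a carboxylic acid at that end.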